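Cytotoxicity notes: benzyl ether in place of 4-bromophenyl

The source may hold more compounds than are shown below. What is called first, only, known or untested is meant among the compounds shown, and "the series" means these compounds.

Among the compounds with values here, compound 2 `CCC1(Cc2ccccc2)OS(=O)(=O)C=C1OCc1ccc(Br)cc1` is the only member of the series with a number in an ADME assay on HEL cells (Homo sapiens) for cytotoxicity, with a stated time of 3 days (on this read-out higher numbers stand for lower toxicity in this test and lower numbers for higher toxicity in this test), where compound 2 gives 80000 nM. Compound 1 `CCC1(Cc2ccccc2)OS(=O)(=O)C=C1OCC(=O)OC` shows only a limit there, namely > 400000 nM. Within the data shown here, the one measured step, an at least 5.0-fold lower number from compound 1 to compound 2 (0.69 log units; beyond the scatter), is judged against that limit of > 400000 nM in this assay, at which 1 of the 2 values shown sits, and therefore reads as a lower bound on its size. Compound 3 `CCC1(Cc2ccccc2)OS(=O)(=O)C=C1OCCc1ccccc1` differs from compound 2 by benzyl in place of 4-bromophenyl on a saturated chain carbon bound to an oxygen on an unsaturated carbon. The measured step changes the same place, yet swaps an ester for an aromatic ring, whereas the step to compound 3 keeps an aromatic ring at that place; the measured step is thus only loosely relevant. The expected step from compound 2 to compound 3 is therefore a 1.3-fold higher number from compound 2 to compound 3 (0.10 log units; within the scatter), within the scatter. Compound 3 is estimated at 100000 nM in this assay, within 40000 nM to 300000 nM.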

Compound 3, minimum cytotoxic concentration: >= 20000 nM
Compound 3 gave a limit, no number; the forecaster's own chance of this, stated with the estimate: 10%; the middle value lies beyond the limit too.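

In this assay compound 3 gives >= 20000 nM, a limit and not a number. Within the data shown here, no step from compound 1 or compound 2 to compound 3 can be read. The compounds shown leave open whether benzyl in place of 4-bromophenyl shifts this read-out at all.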